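Halogen swap on the aryl group of compound 1

The compounds below may be only part of what the source reports. "The series", "measured", "known", "first", "only" and "open" are said of these compounds alone.

Among the measured compounds shown here, in a functional assay on HeLa cells (Homo sapiens) for antiproliferative activity, read by MTT assay, with a stated time of 48 h (a higher number here means a weaker inhibitor of growth, a lower number a stronger inhibitor of growth), compound 1 `Cc1cc2c(c(=O)n1C)C(c1ccc(F)c(Br)c1)C(C#N)=C(N)O2` gives 6400 nM, the only number so far. Compound 2 `Cc1cc2c(c(=O)o1)C(c1cccc(Br)c1)C(C#N)=C(N)O2` reaches only a limit in this assay, > 100000 nM; (the limit of > 100000 nM in this assay, at which 1 of the 2 values shown sits). Compound 3 `Cc1cc2c(c(=O)n1C)C(c1ccc(Cl)c(Cl)c1)C(C#N)=C(N)O2` differs from compound 1 by 3,4-dichlorophenyl in place of 3-bromo-4-fluorophenyl on a saturated ring carbon. For the measured compounds named here, no step between measured compounds shows how this assay answers such a change, so the step from compound 1 to compound 3 is expected to stay within the usual scatter, in no set direction. Compound 3 is expected near 6000 nM, between 2000 nM and 20000 nM, which means a step of a 1.1-fold lower number from compound 1 to compound 3 (0.03 log units; within the scatter).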

Compound 3, concentration for 50% growth inhibition: 18300 nM
For compound 3 the middle estimate is 3.1-fold (0.48 log units) below the measured one; the measured number falls inside the stated range.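

In this assay the aryl group on the saturated ring carbon is not silent: with the core of compound 1 held fixed, 3,4-dichlorophenyl in place of 3-bromo-4-fluorophenyl gives a 2.9-fold higher number from compound 1 to compound 3 (0.46 log units; beyond the scatter). Among the compounds shown here, this is the first step that can be read, and it is modest. Nothing measured here gives a cause for this step.

Both halogens on the ring change together, so the compounds shown leave open which of the two carries the step. Also open, as far as these compounds go, is how this position answers an aryl group bearing a methoxy group or an amine.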